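Swapping Diisopropylamino for Dibutylamino on a Shared Core

The source may report more compounds than this note shows. Statements on the series, on what has been measured and on what is new or still open speak of the compounds shown alone.

Compound 3 `CCCCCCCCCCCCCC[C@H](O)[C@H](CN(C(C)C)C(C)C)NC(=O)OC(C)(C)C` stands second highest of the three numbers measured in a functional assay on MDA-MB-231 cells (Homo sapiens) for antiproliferative activity, read by sulforhodamine B assay, with a stated time of 48 h, tested at 10 uM; a higher number here means more inhibition at the concentration tested (going by the name of the read-out), a lower number less inhibition: compound 3 gives -1.17%, while compound 2 `CCCCCCCCCCCCCC[C@H](O)[C@H](CN(CC)CC)NC(=O)OC(C)(C)C` gives -1.45% and compound 1 `CCCCCCCCCCCCCC[C@H](OCOC)[C@H](CN(CCCC)CCCC)NC(=O)OC(C)(C)C` gives 22.3%. Among the compounds with values here, the only measured step at this position, a number 0.3 percentage points higher from compound 2 to compound 3 (within the scatter), lay within the scatter. Compound 4 `CCCCCCCCCCCCCC[C@H](O)[C@H](CN(CCCC)CCCC)NC(=O)OC(C)(C)C` differs from compound 3 as follows: dibutylamino in place of diisopropylamino on a saturated chain carbon, two bonds along the chain from an amide-type nitrogen. Within the data shown here, compound 1 also carries dibutylamino yet differs from compound 4 elsewhere, so its value offers only a loose hint; no measured step isolates the present change. Compound 4 is therefore expected to give 7% (range -6% to 24%), an expected step of a number 8.2 percentage points higher from compound 3 to compound 4 (within the scatter) that may well stay within the scatter.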

Compound 4, a percentage reported as inhibition, at one concentration (the size of the read-out at that concentration, not a potency): -9.61%
Compound 4: the middle estimate sits 16.6 percentage points above what was measured, outside the stated range (below it).
By their numbers in this assay, from the lowest: compounds 4, 2 and 3 (each within the scatter of the next); then compound 1.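

In this assay the change to dibutylamino gives a number 8.4 percentage points lower from compound 3 to compound 4 (within the scatter) and a number 8.2 percentage points lower from compound 2 to compound 4 (within the scatter) at this position, so the three amines stay together. Hydrogen in place of methoxymethyl on the oxygen gives a number 31.9 percentage points lower from compound 1 to compound 4 (beyond the scatter) and so shows that dibutylamino alone does not carry the inhibition of compound 1. The compounds shown leave open whether methoxymethyl on that oxygen would do the same with diethylamino or diisopropylamino, and how a piperidine or morpholine would read at this position. Nothing available explains these numbers.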